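A few compounds are considered here, and "the series" means these few. Any claim that something is new, unique, unknown or untested is made for them only; others in the source may bear on it.

Compound 1 `CCCCCCCCCCC(C)(C)C(=O)Nc1ccc(C)c(C)c1`: 1660 nM
Compound 2 `CCCCCCCCCCC(C)(C)C(=O)Nc1c(C)cccc1C`: 1300 nM

In an assay on microsomes from intestine for inhibition of acyl-CoA:cholesterol acyltransferase (Oryctolagus cuniculus) (on this read-out higher numbers stand for weaker inhibition and lower numbers for stronger inhibition), compound 1 gives 1660 nM, and compound 2 gives 1300 nM. These two values sit within the scatter of each other, since the step of a 1.3-fold lower number from compound 1 to compound 2 (0.11 log units; within the scatter) does not exceed it; compound 2 therefore stands beside compound 1 rather than apart from it.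

Compound 3 `CCCCCCCCCCC(C)(C)C(=O)Nc1c(C)cc(Br)cc1C` differs from compound 2 by bromo in place of hydrogen on an aromatic carbon, meta to two methyl groups and para to a large group. Going by the values given here, no measured step concerns a bromine atom entering the ring; the single step from compound 1 to compound 2 only moves methyl groups and stays within the scatter. With nothing to bear on the change, no step beyond the scatter is expected in this assay, but the range must be wide. Compound 3 is expected to give about 1100 nM, between 300 nM and 4000 nM. That estimate means a 1.2-fold lower number from compound 2 to compound 3 (0.07 log units; within the scatter).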

Compound 3, half-maximal inhibitory concentration: 410 nM
Beside the measured number, compound 3's estimate is 2.7-fold (0.43 log units) above it; low and high end bracket the measured number.
By their numbers in this assay, from the lowest: compound 3; then compounds 2 and 1 (each within the scatter of the next).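

With bromo in place of hydrogen on the aromatic carbon para to a large group and meta to two methyl groups, this assay shows a 3.2-fold lower number from compound 2 to compound 3 (0.50 log units; beyond the scatter) as a modest change. Going by these compounds alone, the earlier pair showed only that moving the methyl groups, in a 1.3-fold lower number from compound 1 to compound 2 (0.11 log units; within the scatter), leaves the number within the scatter, whereas this result shows that a single heavy atom at this carbon can move it beyond the scatter. The data offer no explanation for why the number falls with this change.

The compounds shown leave open whether this step is particular to bromo or would also appear with chloro, methoxy or an amine on the same carbon. They also leave open whether bromo would give a similar step on the core of compound 1.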